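A few compounds are considered here, and "the series" means these few. Any claim that something is new, unique, unknown or untested is made for them only; others in the source may bear on it.

Compound 1 `N#CNC(=N)NCCCCCn1nc(-c2ccccc2)ccc1=O`: 31% in a functional assay on the whole organism with Rattus norvegicus as the target, at a dose of 100 mg/kg; on this read-out lower numbers stand for less inhibition and higher numbers for more inhibition at the one dose given (going by the name of the read-out).
Compound 2 `C/N=C(/NC#N)NCCCCCn1nc(-c2ccccc2)ccc1=O`: 47.6% in this assay.

Among the compounds with values here, compound 2 stands highest of the two numbers in this assay, and its only neighbour is compound 1. Within the data shown here, the one measured step, a number 16.6 percentage points higher from compound 1 to compound 2 (beyond the scatter), came from putting a group of 6 heavy atoms (3 carbon, 3 nitrogen; no ring) in place of a group of 5 heavy atoms (2 carbon, 3 nitrogen; no ring) on an amine nitrogen.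

Compound 3 `CC/N=C(/NC#N)NCCCCCCn1nc(-c2ccccc2)ccc1=O` is the next compound. It differs from compound 2 by a group of 9 heavy atoms (5 carbon, 4 nitrogen; no ring) in place of a group of 7 heavy atoms (3 carbon, 4 nitrogen; no ring), on a saturated chain carbon, five bonds along the chain from an aromatic nitrogen. Among the measured compounds shown here, this change sits at a different place from the one measured step, so that step gives only a loose guide; it was modest and positive, but nothing measured speaks to a longer chain or the larger terminal group. Compound 3 is therefore expected to show a number 4.4 percentage points higher from compound 2 to compound 3 (within the scatter), a step that need not exceed the scatter. The estimate for compound 3 in this assay is 52%, within 35% to 68%.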

Compound 3, a percentage reported as inhibition, in the whole organism at one dose (the size of the read-out at that dose, not a potency): 29.1%
The estimate for compound 3 lay 22.9 percentage points above the measured number; measured number outside the range, below it.
By their numbers in this assay, from the lowest: compounds 3 and 1 (each within the scatter of the next); then compound 2.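

In this assay, the change on a saturated chain carbon, five bonds along the chain from an aromatic nitrogen, gave a number 18.5 percentage points lower from compound 2 to compound 3 (beyond the scatter), so the rise seen at the amine nitrogen did not carry over to this larger group of 9 heavy atoms. Measured against the group of 6 heavy atoms, the same group gave a number 1.9 percentage points lower from compound 1 to compound 3 (within the scatter), which leaves only the group of 7 heavy atoms standing apart from the other two. No measured evidence bears on why the number fell.

Still open, on these data alone, is which part of the entering group goes with the lower number, the longer chain or the ethyl group at its end, as the two change together in compound 3. As far as these compounds go, how a shorter chain or a propyl group at that end would read in this assay also remains open.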